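Benzofuran Replaces Thiophene on a Nucleoside Core at the Limit

A few compounds are considered here, and "the series" means these few. Any claim that something is new, unique, unknown or untested is made for them only; others in the source may bear on it.

Measured compounds:
compound 1, `Nc1nc(N)c2c(-c3ccsc3)cn([C@@H]3O[C@H](CO)[C@@H](O)[C@H]3O)c2n1`: > 20000 nM
compound 2, `COc1nc(N)nc2c1c(-c1ccsc1)cn2[C@@H]1O[C@H](CO)[C@@H](O)[C@H]1O`: > 20000 nM
compound 3, `Cc1nc(N)c2c(-c3ccsc3)cn([C@@H]3O[C@H](CO)[C@@H](O)[C@H]3O)c2n1`: > 20000 nM

In a functional assay on K562 cells (Homo sapiens), read by MTT assay, with a stated time of 72 h (a higher number here means a weaker inhibitor, a lower number a stronger inhibitor), compound 1 gives > 20000 nM, which is a limit of the assay rather than a number. Compound 2 gives > 20000 nM, again a limit. Compound 3 gives > 20000 nM, also a limit. Compound 1 therefore stands at the limit together with both companions, as the limit of > 20000 nM in this assay, at which 3 of the 3 values shown sit, shows. For the measured compounds named here, the steps a step that the two limits leave unreadable from compound 1 to compound 2 and a step that the two limits leave unreadable from compound 1 to compound 3 are of a size that two limits leave unreadable; they show only that swapping the amino group for methoxy or methyl on the core did not bring a readable value.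

Compound 4, `Nc1nc(N)c2c(-c3cc4ccccc4o3)cn([C@@H]3O[C@H](CO)[C@@H](O)[C@H]3O)c2n1`, differs from compound 1 by 1-benzofuran-2-yl in place of thiophen-3-yl on an aromatic carbon. Going by the values given here, neither measured step touches this part of the core, so none bears directly on the change; they show only that the core has yet to leave the limit. A step of an at least 1.3-fold lower number from compound 1 to compound 4 (0.12 log units; that floor lies within the scatter) is expected, most likely still leaving compound 4 at or near the limit. The estimate for compound 4 is 15000 nM, with a range from 3000 nM to 60000 nM.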

Compound 4, half-maximal inhibitory concentration: 18600 nM
Compound 4: the middle estimate sits 1.2-fold (0.09 log units) below what was measured; the measured number falls inside the stated range.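

Compound 4 alone among the compounds shown gives a readable number rather than a limit in this assay, so the place where 1-benzofuran-2-yl replaces thiophen-3-yl is the only change here that leaves the limit. The size of this change stays uncertain, as the data give only an at least 1.0-fold lower number from compound 1 to compound 4 (0.03 log units; that floor lies within the scatter), so it may be no real gain at all. The limit itself remains the most common result: the limit of > 20000 nM in this assay, at which 3 of the 4 values shown sit.

From the compounds shown here alone, the steps to the methoxy and methyl compounds cannot be read, so it remains open whether either group would make a readable difference on the core of compound 4. Also open, going by these compounds, is whether a phenyl or furan-2-yl group at this position would give a readable value, which would help show whether the fused six-membered ring is needed.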